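A few compounds are considered here, and "the series" means these few. Any claim that something is new, unique, unknown or untested is made for them only; others in the source may bear on it.

Series notes: three compounds share one core and differ only in the group on an amine nitrogen in a ring. Compound 1 `O=C(/C=C/c1ccccc1)c1ccc(N2CCN(c3ccccc3F)CC2)cc1` gives 0.57% in a functional assay on the whole organism (strain Kunming) for inhibition, with Mus musculus as the target, with a stated time of 1 h, at a dose of 40 mg/kg by the oral route; on this read-out lower numbers stand for less inhibition and higher numbers for more inhibition at the one dose given (going by the name of the read-out). Compound 2 `Cc1ccc(N2CCN(c3ccc(C(=O)/C=C/c4ccccc4)cc3)CC2)c(C)c1` gives 15%, and compound 3 `O=C(/C=C/c1ccccc1)c1ccc(N2CCN(c3cccc(Cl)c3Cl)CC2)cc1` gives 30.7%. The steps run a number 14.4 percentage points higher from compound 1 to compound 2 (beyond the scatter), a number 30.1 percentage points higher from compound 1 to compound 3 (beyond the scatter) and a number 15.7 percentage points higher from compound 2 to compound 3 (beyond the scatter). Compound 2 therefore stands second highest of the three numbers, beyond the scatter from compound 1 below it and from compound 3 above it.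

Compound 4 `Cc1ccc(N2CCN(c3ccc(C(=O)/C=C/c4ccc(Cl)cc4)cc3)CC2)c(C)c1` is not yet measured. Against compound 2 the change is chloro in place of hydrogen on an aromatic carbon. This touches a different part of the molecule from every measured step: all three known steps exchange the group on the amine nitrogen in the ring and leave the phenyl untouched, so none of them bears on the phenyl to 4-chlorophenyl change, and their sizes, modest to large, cannot be carried over. Going by the values given here, with no comparable step in hand, the expectation is no change beyond the scatter: compound 4 is estimated at 15%, within 2% to 38%, which means an expected step of no change at the digits printed from compound 2 to compound 4 (within the scatter); the range is kept wide since the change has no precedent here.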

Compound 4, a percentage reported as inhibition, in the whole organism at one dose (the size of the read-out at that dose, not a potency): 25.7%
Beside the measured number, compound 4's estimate is 10.7 percentage points below it, and the stated range covers the measured number.
By their numbers in this assay, from the lowest: compound 1; then compound 2; then compounds 4 and 3 (each within the scatter of the next).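

Phenyl to 4-chlorophenyl gives, in this assay, a number 10.7 percentage points higher from compound 2 to compound 4 (beyond the scatter), which is the first reading from this end of the molecule. The group on the amine nitrogen in the ring is therefore not the only place in the series where the read-out responds: a single chlorine on an aromatic carbon, para to a large group, with no hydrogen-bond donor or acceptor and no net charge, is enough to give a step beyond the scatter. Nothing at hand speaks to what lies behind this step.

Going by these compounds, the reading rests on one pair carrying 2,4-dimethylphenyl on the amine nitrogen, so it remains open whether the same exchange would give a comparable step with 2-fluorophenyl or 2,3-dichlorophenyl there. Also open, on these data alone, is whether the effect belongs to chlorine itself or would be shared by other groups at that place, such as a methoxy group, fluoro, an amine or a carboxylic acid.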